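A few compounds are considered here, and "the series" means these few. Any claim that something is new, unique, unknown or untested is made for them only; others in the source may bear on it.

Measured compounds:
- compound 1, `C/C(=C\c1cc(C2=CCCC2)co1)C(N)=O`, 17600 nM
- compound 2, `C/C(=C\c1ccc(-c2ccc(C)cc2)o1)C(N)=O`, 4590 nM
- compound 3, `C/C(=C\c1cc(-c2ccc(F)cc2)cs1)C(N)=O`, 20800 nM

In a functional assay on HeLa cells (Homo sapiens) for cytotoxicity, read by CCK-8 assay, with a stated time of 24 h (a lower number here means a stronger inhibitor, a higher number a weaker inhibitor), compound 1 gives 17600 nM, compound 2 gives 4590 nM, and compound 3 gives 20800 nM. Of these three numbers, compound 3 has the highest. Its number sits within the usual scatter of compound 1, so no order between these two can be read from the data. The number of compound 2 lies below that of compound 3 by a gap beyond the scatter, so compound 2 is the one of the three that clearly differs from compound 3.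

Compound 4, `C/C(=C\c1cc(-c2ccc(C(F)(F)F)cc2)cs1)C(N)=O`, has not yet been measured in this assay. It differs from compound 3 in one place: trifluoromethyl in place of fluoro on an aromatic carbon, on a six-membered aromatic ring of carbon only, para to a large group. Among the compounds with values here, no pair of measured compounds shows a step of this kind, so there is nothing in the data that points to a direction. The expectation is therefore a step of a 1.0-fold lower number from compound 3 to compound 4 (0.02 log units; within the scatter), not beyond the scatter. Compound 4 is estimated at 20000 nM, in a range from 8000 nM to 50000 nM.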

Compound 4, half-maximal inhibitory concentration: > 50000 nM
Compound 4: only a limit was reported (the forecaster's own chance of this, stated with the estimate: 10%); middle value at least 2.5-fold (0.39 log units) away from the limit.
By their numbers in this assay, from the lowest: compound 2; then compounds 1 and 3 (each within the scatter of the next). At a limit, above all of these: compound 4.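

In this assay compound 4 gives > 50000 nM, which is a limit of the assay and not a number. Within the data shown here, until now no two measured compounds differed in only one place, so nothing showed how this series responds to a single change. Here, putting trifluoromethyl (4 heavy atoms) in place of fluoro (1 heavy atom) on the six-membered aromatic ring of carbon only, para to a large group, gives an at least 2.4-fold higher number from compound 3 to compound 4 (0.38 log units; beyond the scatter), so this position does not tolerate every substituent equally in this cell test, and the change moves the number in the weaker direction. The step gives only a minimum, and its full size cannot be read from the result: the limit of > 50000 nM in this assay, at which 1 of the 4 values shown sits.

This single pair cannot show whether the number rises steadily as the group at this position grows, or whether trifluoromethyl is a special case, and a methyl group, a methoxy group or an amine at the same place would help to separate these possibilities. It also leaves open whether the same exchange would have a similar effect on the core of compound 1 or compound 2.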